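The source may report more compounds than this note shows. Statements on the series, on what has been measured and on what is new or still open speak of the compounds shown alone.

Compound 3 `CCn1c(C(=O)N(CCC#N)CCC#N)ccc1C(CC)(CC)c1ccc(OCC(O)C(C)(C)C)c(C)c1` gives 97 nM in an assay on HL-60 cells for agonist activity at vitamin D3 receptor (Homo sapiens), read by microscopy, with a stated time of 96 h (on this read-out higher numbers stand for an effect only at larger amounts of compound and lower numbers for an effect already at smaller amounts), the lowest of the three numbers in hand. Compound 1 `C#CCNC(=O)c1ccc(C(CC)(CC)c2ccc(OCC(O)C(C)(C)C)c(C)c2)n1CC` gives 240 nM, and compound 2 `CCn1c(C(=O)N(C)c2ccccc2)ccc1C(CC)(CC)c1ccc(OCC(O)C(C)(C)C)c(C)c1` gives 6400 nM. Compound 4 `CCn1c(C(=O)Nc2ccc(OC(F)(F)F)cc2)ccc1C(CC)(CC)c1ccc(OCC(O)C(C)(C)C)c(C)c1` differs from compound 3 by a group of 12 heavy atoms (7 carbon, 1 nitrogen, 1 oxygen, 3 fluorine; one six-membered aromatic ring of carbon only) in place of a group of 9 heavy atoms (6 carbon, 3 nitrogen; no ring), on a carbonyl carbon. Among the measured compounds shown here, two measured steps bear on this change: a 66-fold lower number from compound 2 to compound 3 (1.82 log units; beyond the scatter), and a 2.5-fold lower number from compound 1 to compound 3 (0.39 log units; beyond the scatter). The first step shows that an aromatic ring with no amide hydrogen on the carbonyl nitrogen went with a much higher number than the bis-nitrile group; the second shows that a smaller group carrying an amide hydrogen, as in compound 1, sat only modestly higher than compound 3. Compound 4 carries both the ring and the amide hydrogen, so a rise is expected, though not as large as the step that leads to compound 2, and the expected step is a 6.2-fold higher number from compound 3 to compound 4 (0.79 log units; beyond the scatter). Compound 4 is therefore estimated at 600 nM in this assay, with a range from 120 nM to 3500 nM.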

Compound 4, half-maximal effective concentration: > 50000 nM
Compound 4: no number, only a limit; the forecaster's own chance of this, stated with the estimate: 5%; at least 83-fold (1.92 log units) between middle value and limit.
By their numbers in this assay, from the lowest: compound 3; then compound 1; then compound 2. At a limit, above all of these: compound 4.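

Compound 4 gives no number in this read-out, only a limit: the limit of > 50000 nM in this assay, at which 1 of the 4 values shown sits. With (4-(trifluoromethoxy)phenyl)amino on this carbonyl carbon, the distance from the group with the two nitriles is an at least 510-fold higher number from compound 3 to compound 4 (2.71 log units; beyond the scatter), and the distance from propargylamino is an at least 200-fold higher number from compound 1 to compound 4 (2.31 log units; beyond the scatter). Even measured against methyl(phenyl)amino, the previous top of the series, the change gives an at least 7.8-fold higher number from compound 2 to compound 4 (0.89 log units; beyond the scatter), so a ring on this amide nitrogen did not sit lower once the amide hydrogen was present alongside the trifluoromethoxy group.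

The compounds shown leave open whether the ring or the trifluoromethoxy group goes with this rise, a question that plain phenylamino or 4-methoxyphenylamino in the same place would help to settle. They also leave open how a ring without an aromatic system, such as morpholine, would read on this carbonyl carbon.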